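Swapping a Thiazole Back for a Fluorinated Pyrimidine Ether

This account rests on a few compounds, and the source may have more. Where it says the series, first, only, none or still open, it means among the compounds named here.

Measured so far:
compound 1 `O=C1CC(Oc2ncccn2)CN1c1cnn2c1CN(C(=O)Nc1cc(F)c(F)c(F)c1)C(C1CC1)C2`: > 200000 nM
compound 2 `O=C1CC(c2cnc(C(F)(F)F)s2)CN1c1cnn2c1CN(C(=O)Nc1cc(F)c(F)c(F)c1)C(C1CC1)C2`: 38500 nM

In a toxicity assay on HepG2 2.2.15 cells (Homo sapiens) for cytotoxicity, read by CellTiter-Glo (on this read-out higher numbers stand for lower toxicity in this test and lower numbers for higher toxicity in this test), compound 1 gives only a limit of the assay, > 200000 nM. Compound 2 gives 38500 nM in this assay, and this is the only true number shown. Within the data shown here, the single measured step is an at least 5.1-fold lower number from compound 1 to compound 2 (0.71 log units; beyond the scatter). Compound 3 `O=C1CC(Oc2ncc(F)cn2)CN1c1cnn2c1CN(C(=O)Nc1cc(F)c(F)c(F)c1)C(C1CC1)C2` differs from compound 2 in one place: (5-fluoropyrimidin-2-yl)oxy in place of 2-(trifluoromethyl)-1,3-thiazol-5-yl on a saturated ring carbon. Among the measured compounds shown here, the group that enters closely resembles the one compound 1 carries, so this change largely reverses the measured step. The step in this assay is therefore expected to run upward, back toward the limit recorded for compound 1 (the limit of > 200000 nM in this assay, at which 1 of the 2 values shown sits), with a fair chance that only a limit is reported again. For compound 3 the estimate is 150000 nM, within 50000 nM to 300000 nM. The expected step is a 3.9-fold higher number from compound 2 to compound 3 (0.59 log units; beyond the scatter).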

Compound 3, half-maximal cytotoxic concentration: 96200 nM
For compound 3 the middle estimate is 1.6-fold (0.19 log units) above the measured one, and the stated range covers the measured number.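

In this assay, putting (5-fluoropyrimidin-2-yl)oxy in place of 2-(trifluoromethyl)-1,3-thiazol-5-yl on the saturated ring carbon gives a 2.5-fold higher number from compound 2 to compound 3 (0.40 log units; beyond the scatter), so the group at this position can move the number in either direction. A single fluoro in place of hydrogen on an aromatic carbon gives an at least 2.0-fold lower number from compound 1 to compound 3 (0.31 log units; beyond the scatter), showing that the two pyrimidine ethers are not interchangeable in this test. The size of that last step remains open-ended, as the value for compound 1 is only a limit of the assay: the limit of > 200000 nM in this assay, at which 1 of the 3 values shown sits.

Still open, going by these compounds, is whether fluoro is unusual here or whether chloro, methyl or an amine on the pyrimidine would shift the number similarly. It is also unclear how much the ether oxygen contributes, a question that a pyrimidin-2-yl group joined directly to the saturated ring carbon could address.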